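The source may report more compounds than this note shows. Statements on the series, on what has been measured and on what is new or still open speak of the compounds shown alone.

Compound 1 `O=C(O)COc1ccc([C@H]2CC[C@]3(CC2)OOC2(O3)C3CC4CC(C3)CC2C4)cc1Cl`: < 3.1 ug/mL, a limit of the assay
Compound 2 `O=C(O)COc1ccc([C@H]2CC[C@]3(CC2)OOC2(O3)C3CC4CC(C3)CC2C4)cc1`: < 1.6 ug/mL, a limit of the assay

Both compounds were measured in a physicochemical assay for solubility, read by nephelometry, in phosphate buffer, measured as kinetic solubility, with a stated time of 30 min, at pH 6.5; on this read-out lower numbers stand for lower solubility and higher numbers for higher solubility. Compound 1 therefore has no numerical value in this assay, only the limit < 3.1 ug/mL, and the one other result available is also a limit.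

Compound 3 `O=C(O)COc1c(Cl)cc([C@H]2CC[C@]3(CC2)OOC2(O3)C3CC4CC(C3)CC2C4)cc1Cl` differs from compound 1 at one place: chloro in place of hydrogen on an aromatic carbon. Chloro takes the place of hydrogen on an aromatic carbon, ortho to a carboxymethoxy group, meta to a chloro group and meta to a large group.

Among the measured compounds shown here, one measured step bears on this change: a step that the two limits leave unreadable from compound 1 to compound 2. It is the reverse kind of exchange, hydrogen in place of chloro, and it has no readable size or direction. The data therefore give no basis for expecting a shift either way, and no step beyond the scatter is expected. The expected step is a step that the limit leaves unreadable from compound 1 to compound 3. A reading that is again only a limit is the likeliest outcome in this assay. For compound 3 the estimate is 1.5 ug/mL, with an expected range from 0.5 ug/mL to 3.1 ug/mL.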

Compound 3, solubility: < 3.1 ug/mL
Compound 3 ended at the assay's limit (the forecaster's own chance of this, stated with the estimate: 90%); the middle value does not contradict the limit.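

In this assay compound 3 gives < 3.1 ug/mL, which is a limit of the assay and not a number. Compound 1 also stands at a limit, and no step can be read between compound 1 and compound 3. The compounds shown leave open whether chloro in place of hydrogen on an aromatic carbon shifts the solubility read-out in either direction.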